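This account rests on a few compounds, and the source may have more. Where it says the series, first, only, none or still open, it means among the compounds named here.

Values in a functional assay on HepG2 cells (Homo sapiens) for inhibition, read by MTT assay, with a stated time of 72 h; a lower number here means a stronger inhibitor, a higher number a weaker inhibitor:
Compound 1, `CN(C(=O)NC(=O)c1cccc(C(F)(F)F)c1)c1nc(C(F)(F)F)c(C(=O)N/N=C/c2cccc(C(F)(F)F)c2)s1`: 5.79 ug/mL
Compound 2, `CN(C(=O)NC(=O)c1ccccc1F)c1nc(C(F)(F)F)c(C(=O)N/N=C/c2ccc(C(F)(F)F)cc2)s1`: 4.56 ug/mL
Compound 3, `CN(C(=O)NC(=O)c1ccc([N+](=O)[O-])cc1)c1nc(C(F)(F)F)c(C(=O)N/N=C/c2cccc(C(F)(F)F)c2)s1`: 4.73 ug/mL

Compound 2 gives the lowest of the three numbers in this assay, but compound 3, its nearest neighbour, sits within the scatter of it, and so does compound 1; the three values cannot be ranked. Within the data shown here, the one single-point step among them, a 1.2-fold lower number from compound 1 to compound 3 (0.09 log units; within the scatter), did not move the number beyond the scatter either.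

Compound 4, `CN(C(=O)NC(=O)c1ccc(Cl)cc1Cl)c1nc(C(F)(F)F)c(C(=O)N/N=C/c2ccc(C(F)(F)F)cc2)s1`, is the next member. It differs from compound 2 in one place: 2,4-dichlorophenyl in place of 2-fluorophenyl on a carbonyl carbon. Among the measured compounds shown here, no measured step covers this exact change. For the measured compounds named here, the only comparable step, in which one aryl group on the carbonyl carbon was exchanged for another, is a 1.2-fold lower number from compound 1 to compound 3 (0.09 log units; within the scatter), and that stayed within the scatter. Compound 1 and compound 2 differ at that carbonyl and also elsewhere, and their values still lie within the scatter of each other. On this basis the exchange of one aryl group for another at this carbonyl is expected to leave the number in this assay close to where compound 2 stands, with no step beyond the scatter; the estimated step is a 1.1-fold higher number from compound 2 to compound 4 (0.02 log units; within the scatter). Compound 4 is therefore expected at 4.8 ug/mL, between 2.5 ug/mL and 9.5 ug/mL.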

Compound 4, half-maximal inhibitory concentration: 12.4 ug/mL
Estimate against measurement, compound 4: 2.6-fold (0.41 log units) below; measured number outside the range, above it.
By their numbers in this assay, from the lowest: compounds 2, 3 and 1 (each within the scatter of the next); then compound 4.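

Notes on the carbonyl aryl position: in this assay the exchange of 2-fluorophenyl for 2,4-dichlorophenyl gives a 2.7-fold higher number from compound 2 to compound 4 (0.43 log units; beyond the scatter) and is the first single-place step in this set to pass beyond the scatter, although its size is modest. The position is therefore not indifferent to the choice of aryl group, a point that could not be seen from a 1.2-fold lower number from compound 1 to compound 3 (0.09 log units; within the scatter) within the scatter, where 4-nitrophenyl replaced 3-(trifluoromethyl)phenyl at the same carbonyl carbon on a parent that also differs from compound 2 elsewhere. Nothing measured here bears on why this exchange moves the number when the earlier one did not.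

The compounds shown do not separate the two parts of this exchange, so 2-chlorophenyl and 4-chlorophenyl would be needed to tell whether the step follows the loss of fluorine or the chlorine named at the 4 position of the ring. Also open, going by these compounds, are whether the step carries over to the parent of compound 1 and compound 3, and how an aryl group bearing an amine or a carboxylic acid would read in this position.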